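Sulfone series: amine ring change in compound 4

The compounds below may be only part of what the source reports. "The series", "measured", "known", "first", "only" and "open" are said of these compounds alone.

Compound 1 `O=S(=O)(c1ccccc1)c1nc2ccccc2nc1N1CCCC1` gives 20800 nM in a functional assay on PC-3 cells (Homo sapiens) for cytotoxicity, read by MTT assay, with a stated time of 72 h; on this read-out higher numbers stand for weaker inhibition and lower numbers for stronger inhibition.
Compound 3 `O=S(=O)(c1ccc(F)cc1)c1nc2ccccc2nc1N1CCCC1` gives 12400 nM in this assay.
Compound 2 `COc1ccc(S(=O)(=O)c2nc3ccccc3nc2N2CCCC2)cc1` gives > 50000 nM in this assay, which is a limit of the assay and not a number.

Compound 1 holds the highest of the two numbers; the nearest step is a 1.7-fold lower number from compound 1 to compound 3 (0.22 log units; within the scatter). The other measured steps, an at least 2.4-fold higher number from compound 1 to compound 2 (0.38 log units; beyond the scatter) and an at least 4.0-fold lower number from compound 2 to compound 3 (0.60 log units; beyond the scatter), like the first, all alter a substituent on an aromatic carbon and leave the pyrrolidin-1-yl untouched. Compound 4 `O=S(=O)(c1ccccc1)c1nc2ccccc2nc1N1CCCC(O)C1` differs from compound 1 elsewhere: 3-hydroxypiperidin-1-yl in place of pyrrolidin-1-yl on an aromatic carbon. Within the data shown here, no measured step touches this part of the shared core, so none bears on the change. With nothing pointing either way, compound 4 is expected to land near compound 1, the expected step being a 1.2-fold higher number from compound 1 to compound 4 (0.08 log units; within the scatter), not beyond the scatter. The estimate for compound 4 in this assay is 25000 nM, between 9000 nM and 80000 nM.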

Compound 4, half-maximal inhibitory concentration: 2100 nM
For compound 4 the middle estimate is 12-fold (1.08 log units) above the measured one; measured number below the stated range.
By their numbers in this assay, from the lowest: compound 4; then compounds 3 and 1 (each within the scatter of the next). At a limit, above all of these: compound 2.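

The amine position on the shared core moves the number in this assay: 3-hydroxypiperidin-1-yl in place of pyrrolidin-1-yl gives a 9.9-fold lower number from compound 1 to compound 4 (1.00 log units; beyond the scatter). Among these compounds, the earlier steps changed only a substituent on an aromatic carbon, so this is the first sign that the amine ring itself matters. Nothing measured here accounts for the step.

As far as these compounds go, the step changes ring size and adds a hydroxy group at once, so the share of each stays open. Piperidin-1-yl and a pyrrolidine ring carrying a hydroxy group would separate the two.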